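Benzyl in Place of Phenyl on the Purine Amine

The compounds below may be only part of what the source reports. "The series", "measured", "known", "first", "only" and "open" are said of these compounds alone.

Compound 1 `COc1ccc(C(=O)O[C@@H]2[C@H](OC(=O)c3ccc(OC)cc3)[C@@H](COP(=O)(O)OP(=O)(O)OP(=O)(O)O)O[C@H]2n2cnc3c(N)ncnc32)cc1` gives in an assay on HEK293 cells for agonist activity at P2X purinoceptor 7 (Homo sapiens), read by fluorescence, with stated times of 30 min and 2 h (on this read-out lower numbers stand for stronger inhibition and higher numbers for weaker inhibition), only a limit, > 100000 nM.
Compound 2 `O=P(O)(O)OP(=O)(O)OP(=O)(O)OC[C@H]1O[C@@H](n2cnc3c(Nc4ccccc4)ncnc32)[C@H](O)[C@@H]1O` gives in this assay only a limit, > 100000 nM.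

Compound 2 thus stands at the edge of what this assay can report, not at a number; (the limit of > 100000 nM in this assay, at which 2 of the 2 values shown sit). Compound 3 `O=P(O)(O)OP(=O)(O)OP(=O)(O)OC[C@H]1O[C@@H](n2cnc3c(NCc4ccccc4)ncnc32)[C@H](O)[C@@H]1O` differs from compound 2 by benzyl in place of phenyl on a nitrogen on an aromatic ring, or anilino to benzylamino when cut one bond further out. Within the data shown here, no step between two measured compounds that differ in one place is available, so the size of the change can only be guessed from the structures. The step that the limit leaves unreadable from compound 2 to compound 3 is expected to stay within the scatter, with no move beyond it in either direction. Compound 3 is therefore estimated to give 150000 nM, with a range from 30000 nM to 1000000 nM, and most probably again only a limit.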

Compound 3, half-maximal inhibitory concentration: > 100000 nM
Compound 3: a limit, no number (the forecaster's own chance of this, stated with the estimate: 80%); the middle value lies beyond the limit too.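

In this assay compound 3 gives > 100000 nM as a limit, not a number. Compound 2 also sits at a limit, so no step between compound 2 and compound 3 can be read: the limit of > 100000 nM in this assay, at which 3 of the 3 values shown sit.

In this assay the compounds shown leave open what benzyl in place of phenyl on a nitrogen on an aromatic ring does to inhibition.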